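Putting a chain back on compound 2

The compounds below may be only part of what the source reports. "The series", "measured", "known", "first", "only" and "open" are said of these compounds alone.

Compound 1 `C=CCCCCOc1ccccc1-c1cnc(OCCCC=C)n1C` gives 5000 nM
Compound 2 `C=CCCCCOc1ccccc1-c1cnc(OC)n1C` gives > 100000 nM, which is a limit

In a functional assay on U-373MG ATCC cells (Homo sapiens) for inhibition, read by colorimetric assay and MTT assay, with a stated time of 72 h (on this read-out lower numbers stand for stronger inhibition and higher numbers for weaker inhibition), compound 1 gives 5000 nM. Compound 2 has only a limit in this assay and no number: the limit of > 100000 nM in this assay, at which 1 of the 2 values shown sits.

The change to compound 3 `C=CCCCCOc1ccccc1-c1cnc(OCCOCC=C)n1C` is this: (allyloxy)methyl in place of hydrogen on a saturated chain carbon bound to an oxygen on an aromatic ring. For the measured compounds named here, one measured step bears on it: an at least 20-fold higher number from compound 1 to compound 2 (1.30 log units; beyond the scatter), large and beyond the scatter, with hydrogen in place of but-3-en-1-yl at the same kind of place. Compound 3 carries a chain there again, though not the same one as compound 1, so a large move to a lower number is expected. The estimated change is an at least 10-fold lower number from compound 2 to compound 3 (1.00 log units; beyond the scatter). For compound 3 the estimate is 10000 nM, with an expected range from 2500 nM to 50000 nM.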

Compound 3, half-maximal inhibitory concentration: 60000 nM
For compound 3 the middle estimate is 6.0-fold (0.78 log units) below the measured one, and the stated range ends below it.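

Compound 3 shows that a chain at this place does not by itself bring back the level of compound 1. With allyloxy in place of allyl, the result is a 12-fold higher number from compound 1 to compound 3 (1.08 log units; beyond the scatter), so what the chain is made of matters here as well as its presence. The step from the methoxy side reads an at least 1.6-fold lower number from compound 2 to compound 3 (0.22 log units; that floor lies within the scatter), and this is only a floor, since compound 2 has a limit and no number: the limit of > 100000 nM in this assay, at which 1 of the 3 values shown sits.

The compounds shown leave open whether the drop comes from the oxygen itself or from where it sits along the chain. They also leave open how an amine or a carboxylic acid at the end of this chain, or a longer all-carbon chain, would compare with compound 1.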